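Swapping a chlorophenyl for a benzodioxin ring

The source may report more compounds than this note shows. Statements on the series, on what has been measured and on what is new or still open speak of the compounds shown alone.

Two sulfonamides have been measured so far. In a functional assay on Capan-2 cells (Homo sapiens) for inhibition, read by MTT assay, with a stated time of 72 h (on this read-out higher numbers stand for weaker inhibition of growth and lower numbers for stronger inhibition of growth), compound 1 `O=S(=O)(NCCCNCc1ccc(Cl)cc1)c1cc(C(F)(F)F)cc(C(F)(F)F)c1` gives 2700 nM, and in this assay compound 2 `O=S(=O)(NCCNCc1ccc(-c2ccccc2)cc1)c1cc(C(F)(F)F)cc(C(F)(F)F)c1` gives 2400 nM; these two numbers lie within the usual scatter of each other, so neither stands apart. Compound 3 `O=S(=O)(NCCCNCC1COc2ccccc2O1)c1cc(C(F)(F)F)cc(C(F)(F)F)c1` has not yet been measured. It arises from compound 1 by one change: 2,3-dihydro-1,4-benzodioxin-2-yl in place of 4-chlorophenyl on a saturated chain carbon bound to an amine nitrogen. Going by the values given here, no measured pair shows what such a change does here, so the step of a 1.3-fold higher number from compound 1 to compound 3 (0.11 log units; within the scatter) is expected to be small, in either direction or none beyond the scatter. For compound 3 the estimate is 3500 nM, with a range from 1200 nM to 10000 nM.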

Compound 3, concentration for 50% growth inhibition: 2500 nM
Compound 3: the middle estimate sits 1.4-fold (0.15 log units) above what was measured, and the stated range covers the measured number.
By their numbers in this assay, from the lowest: compounds 2, 3 and 1 (each within the scatter of the next).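

The first step read at this place, a 1.1-fold lower number from compound 1 to compound 3 (0.03 log units; within the scatter) in this assay, shows that the number can stay within the scatter when 4-chlorophenyl gives way to 2,3-dihydro-1,4-benzodioxin-2-yl. The swap removes the chlorine and brings in a non-aromatic ring with 2 hetero atoms and 2 hydrogen-bond acceptors, yet growth inhibition stays level. Nothing available explains this result.

Going by these compounds, what a morpholine or a carboxylic acid would do on this same saturated chain carbon remains open. So does whether a group much smaller than either ring, such as a methyl, would be tolerated equally well.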